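The source may hold more compounds than are shown below. What is called first, only, known or untested is meant among the compounds shown, and "the series" means these compounds.

Compound 1 `NCCOc1ccc([C@H]2CC[C@]3(CC2)OOC2(O3)C3CC4CC(C3)CC2C4)cc1` gives 1370 ng.h/mL
Compound 2 `c1cc([C@H]2CC[C@]3(CC2)OOC2(O3)C3CC4CC(C3)CC2C4)ccc1OCCC1CCNCC1` gives 16000 ng.h/mL
Compound 3 `c1cc([C@H]2CC[C@]3(CC2)OOC2(O3)C3CC4CC(C3)CC2C4)ccc1OC1CCNCC1` gives 7200 ng.h/mL

In an ADME assay on the whole organism (strain FVB) for pharmacokinetics, with Mus musculus as the target, read by LC-MS, at a dose of 30 mg/kg by the oral route (on this read-out higher numbers stand for higher exposure at the dose given and lower numbers for lower exposure), compound 2 stands highest of the three (16000 ng.h/mL). Compound 4 `O[C@H]1CC[C@H](NCCCOc2ccc([C@H]3CC[C@]4(CC3)OOC3(O4)C4CC5CC(C4)CC3C5)cc2)CC1` departs from it by one change (((4-hydroxycyclohexyl)amino)methyl in place of piperidin-4-yl on a saturated chain carbon, two bonds along the chain from an oxygen on an aromatic ring), with ((4-hydroxycyclohexyl)amino)methyl in place of piperidin-4-yl on a saturated chain carbon. For the measured compounds named here, two measured steps bear on this. The step from amino to piperidin-4-yl at that carbon was large (a 12-fold higher number from compound 1 to compound 2 (1.07 log units; beyond the scatter)), and the step to piperidin-4-yl on the oxygen was modest (a 2.2-fold lower number from compound 2 to compound 3 (0.35 log units; beyond the scatter)). Both compounds sit lower than compound 2, but neither carries the entering group, so in this assay a modest fall is expected (a 3.2-fold lower number from compound 2 to compound 4 (0.51 log units; beyond the scatter)). Compound 4 is estimated at 5000 ng.h/mL with an expected range of 1500 ng.h/mL to 15000 ng.h/mL in this measurement.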

Compound 4, area under the concentration-time curve: 6570 ng.h/mL
Estimate against measurement, compound 4: 1.3-fold (0.12 log units) below, within the range that was stated.
By their numbers in this assay, from the lowest: compound 1; then compounds 4 and 3 (each within the scatter of the next); then compound 2.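

In this assay, the saturated chain carbon two bonds along the chain from an oxygen on an aromatic ring tolerates a larger group with a carbon-only ring: ((4-hydroxycyclohexyl)amino)methyl in place of piperidin-4-yl gives only (a 2.4-fold lower number from compound 2 to compound 4 (0.39 log units; beyond the scatter)). That group keeps most of the gain over amino (a 4.8-fold higher number from compound 1 to compound 4 (0.68 log units; beyond the scatter)). It also cannot be told apart from compound 3, which has piperidin-4-yl on the oxygen (a 1.1-fold lower number from compound 3 to compound 4 (0.04 log units; within the scatter)).

No measurement given here explains these differences. On these data alone, how a plain cyclohexylamino group, or a carboxylic acid in place of the hydroxy group, would read remains open.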